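A few compounds are considered here, and "the series" means these few. Any claim that something is new, unique, unknown or untested is made for them only; others in the source may bear on it.

Compound 1 `O=C(O)c1cn(Cc2ccc(-n3cnc4ccccc43)cc2)c2cccc(F)c2c1=O` gives 96.1%
Compound 2 `O=C(O)c1cn(Cc2ccc(-n3ccc4cccnc43)cc2)c2cccc(F)c2c1=O` gives 98.8%
Compound 3 `O=C(O)c1cn(Cc2ccc(-n3ccc4cnccc43)cc2)c2cccc(F)c2c1=O` gives 98.2%

In an ADME assay on a cell-free system (plasma, Homo sapiens) for protein binding, with Plasma (Rattus norvegicus) as the target, compound 3 sits with compound 2 and apart from compound 1. The next compound is compound 4 `O=C(O)c1cn(Cc2ccc(-n3ccc4ncccc43)cc2)c2cccc(F)c2c1=O`, and the change is a group of 9 heavy atoms (7 carbon, 2 nitrogen; one five-membered aromatic ring with 1 hetero atom, one six-membered aromatic ring with 1 hetero atom) in place of a group of 9 heavy atoms (7 carbon, 2 nitrogen; one five-membered aromatic ring with 1 hetero atom, one six-membered aromatic ring with 1 hetero atom), on an aromatic carbon with the same atoms joined differently, para to a large group. Among the measured compounds shown here, the closest precedent is the exchange of one such group for its isomer in a 1.5-fold higher unbound fraction from compound 2 to compound 3 (0.18 log units; within the scatter) (within the scatter). The steps a 3.3-fold lower unbound fraction from compound 1 to compound 2 (0.51 log units; beyond the scatter) and a 2.2-fold lower unbound fraction from compound 1 to compound 3 (0.34 log units; beyond the scatter) are larger but swap a different kind of group, so they bear less on this change. The expected step is a 1.1-fold higher unbound fraction from compound 3 to compound 4 (0.05 log units; within the scatter) and so none beyond the scatter. For compound 4 the estimate is 98% with an expected range of 96.5% to 99% in this assay for now.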

Compound 4, plasma protein binding: 96.1%
Compound 4: the middle estimate sits 2.0-fold (0.29 log units) (unbound fraction) below what was measured; measured number below the stated range.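

In this assay, joining the same atoms differently at this place is not a neutral exchange: (a 2.2-fold higher unbound fraction from compound 3 to compound 4 (0.34 log units; beyond the scatter)) and (a 3.3-fold higher unbound fraction from compound 2 to compound 4 (0.51 log units; beyond the scatter)) both lie beyond the scatter, while the earlier exchange of isomers stayed within it. The third step (no change at the digits printed from compound 1 to compound 4 (within the scatter)) shows that this isomer cannot be told apart from the group with two hetero atoms in its five-membered ring. Nothing available explains the gap between the isomers. From the compounds shown here alone, whether an amine on the entering group's six-membered aromatic ring would shift the read-out remains open.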